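Cutting back the chain of compound 1

The compounds below may be only part of what the source reports. "The series", "measured", "known", "first", "only" and "open" are said of these compounds alone.

Among the measured compounds shown here, in a functional assay on CNE-2 cells (Homo sapiens) for inhibition, read by MTT assay, with a stated time of 72 h (on this read-out higher numbers stand for weaker inhibition and lower numbers for stronger inhibition), compound 1 (`Nc1ncnc2c1c(-c1cnc3[nH]ccc3c1)nn2CCCCCCCCC(=O)NO`) gives 2270 nM as the only true number. Compound 2 (`Nc1nc2cc(-c3nn(CCCC(=O)NO)c4ncnc(N)c34)ccc2o1`) reads > 50000 nM and this is a limit. Compound 3 (`Nc1nc2cc(-c3nn(CCCCC(=O)NO)c4ncnc(N)c34)ccc2o1`) reads > 50000 nM and this too is a limit. Their shared core is known so far only through the limit of > 50000 nM in this assay, at which 2 of the 3 values shown sit, and a step that the two limits leave unreadable from compound 2 to compound 3 offers no guide.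

Compound 4 (`Nc1ncnc2c1c(-c1cnc3[nH]ccc3c1)nn2CCCC(=O)NO`) keeps the core of compound 1 and has hydroxycarbamoyl in place of 5-(hydroxycarbamoyl)pentyl on a saturated chain carbon, three bonds along the chain from an aromatic nitrogen. Compound 2 carries the same short chain on its own core and reads > 50000 nM as a limit, so weakening is expected, though no measured step sizes it. The expected change is an 11-fold higher number from compound 1 to compound 4 (1.04 log units; beyond the scatter) and it is estimated to lie beyond the scatter. Compound 4 is estimated in this assay at 25000 nM with 6000 nM to 80000 nM as its range.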

Compound 4, half-maximal inhibitory concentration: > 150000 nM
Compound 4 ended at the assay's limit; the forecaster's own chance of this, stated with the estimate: 45%; middle value at least 6.0-fold (0.77 log units) away from the limit.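

Among the compounds shown here, replacing 5-(hydroxycarbamoyl)pentyl with hydroxycarbamoyl on a saturated chain carbon, three bonds along the chain from an aromatic nitrogen, gives an at least 66-fold higher number from compound 1 to compound 4 (1.82 log units; beyond the scatter) in this assay, the first readable step. On this core, the length of the chain ending in hydroxycarbamoyl therefore matters at this position. Compound 4 reads > 150000 nM, and this is a limit: the limit of > 150000 nM in this assay, at which 1 of the 4 values shown sits.

Chains of intermediate length could show where the number begins to rise, and a longer chain could show whether it falls further. A carboxylic acid in place of the terminal hydroxycarbamoyl would test whether that end group is needed.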